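The source may hold more compounds than are shown below. What is called first, only, known or untested is meant among the compounds shown, and "the series" means these compounds.

Series notes. In a functional assay with Rattus norvegicus as the target (on this read-out higher numbers stand for weaker inhibition and lower numbers for stronger inhibition), compound 3 `CN(C)c1ccc(C(=O)/C=C/c2ccncc2)cc1` gives 11000 nM. Compound 2 `CN(C)c1cccc(C(=O)/C=C/c2ccncc2)c1` gives 19000 nM; compound 2 and compound 3 hold the same atoms joined differently, and the difference between the two cores is not broken down here. Compound 1 `N#Cc1ccc(C(=O)/C=C/c2ccncc2)cc1` gives 123000 nM. From compound 3 to compound 1 the change is cyano in place of dimethylamino on an aromatic carbon, and the step is an 11-fold higher number from compound 3 to compound 1 (1.05 log units; beyond the scatter). Compound 4 `N#Cc1cccc(C(=O)/C=C/c2ccncc2)c1` awaits measurement; from compound 2 it carries cyano in place of dimethylamino on an aromatic carbon. This is the same kind of change, not the same: the place is para to a large group in compound 1 but meta to a large group in compound 4. Resting on an 11-fold higher number from compound 3 to compound 1 (1.05 log units; beyond the scatter) as the one measured instance, the expected step is an 11-fold higher number from compound 2 to compound 4 (1.02 log units; beyond the scatter). Compound 4 is thus estimated at 200000 nM, expected between 60000 nM and 600000 nM.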

Compound 4, half-maximal inhibitory concentration: 85000 nM
The estimate for compound 4 lay 2.4-fold (0.37 log units) above the measured number, within the range that was stated.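

In this assay, cyano in place of dimethylamino on an aromatic carbon gives a 4.5-fold higher number from compound 2 to compound 4 (0.65 log units; beyond the scatter). Set beside the earlier instance, the step runs in the same direction and cannot be told apart in size: the same change on two cores in this assay, an 11-fold higher number (1.05 log units; beyond the scatter) from compound 3 to compound 1 and a 4.5-fold higher number (0.65 log units; beyond the scatter) from compound 2 to compound 4, 2.5-fold (0.40 log units) apart, within the scatter of two such steps. The change therefore carries between these two cores, but two pairs say nothing about other cores and give no explanation for the step.

On these data alone, only dimethylamino and cyano are compared at these places, so it remains open how a primary amine, a methoxy group or a carboxylic acid would read on either core.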